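This account rests on a few compounds, and the source may have more. Where it says the series, first, only, none or still open, it means among the compounds named here.

The measured compounds, all in an assay on cells for inhibition of HSP60/HSP10 (Homo sapiens), with a stated time of 60 min; a lower number here means a stronger inhibitor, a higher number a weaker inhibitor:

Compound 1 `O=S(=O)(Nc1ccc(-c2nc3ccccc3o2)cc1)c1ccccc1O` gives > 100000 nM, a limit of the assay.
Compound 2 `CCc1ccc(S(=O)(=O)Nc2ccc3oc(-c4ccccc4)nc3c2)cc1` gives > 100000 nM, a limit of the assay.
Compound 3 `CCc1ccc(S(=O)(=O)Nc2ccc(-c3nc4ccccc4o3)cc2)cc1` gives > 100000 nM, a limit of the assay.

All three values sit at the limit of > 100000 nM in this assay, at which 3 of the 3 values shown sit. The comparison of compound 3 with compound 1 is the change (2-hydroxyphenyl in place of 4-ethylphenyl on a sulfonyl sulfur), and the step it made is a step that the two limits leave unreadable from compound 3 to compound 1. Compound 2 and compound 3 are built from the same atoms joined differently; the difference between the two cores is not broken down here, and the two values show only that each is a limit.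

Compound 4 `O=S(=O)(Nc1ccc2oc(-c3ccccc3)nc2c1)c1ccccc1O` is not yet measured in this assay. For the measured compounds named here, its relation to compound 2 is 2-hydroxyphenyl in place of 4-ethylphenyl on a sulfonyl sulfur, the same change as the one from compound 3 to compound 1, made at the same place. Since the step from compound 3 to compound 1 could not be read off from its two limits, and since compound 2 itself gives only a limit, compound 4 is expected to land at the limit as well. The step that this estimate means is expected to be a step that the limit leaves unreadable from compound 2 to compound 4. In this assay compound 4 is therefore estimated at 200000 nM, with a likely range from 100000 nM to 1000000 nM.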

Compound 4, half-maximal inhibitory concentration: 85000 nM
For compound 4 the middle estimate is 2.4-fold (0.37 log units) above the measured one; measured number outside the range, below it.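

In this assay, 2-hydroxyphenyl in place of 4-ethylphenyl on a sulfonyl sulfur gives an at least 1.1-fold lower number from compound 2 to compound 4 (0.07 log units; that floor lies within the scatter), and with this change the core of compound 2 yields a measured number, compound 4 at 85000 nM. Compound 2 gives > 100000 nM, which is a limit of the assay, so the true size of this step is not known and only its floor is printed, a floor that lies within the scatter. The same change on the core of compound 3 cannot be read, since both of its ends are limits, and the series therefore does not show whether the change carries over from one core to the other or behaves differently on each: the limit of > 100000 nM in this assay, at which 3 of the 4 values shown sit.

The compounds shown leave open whether any group on the sulfonyl sulfur can bring this series clearly away from the limit, and whether a measured number would also appear on the core of compound 3 with another group. They also leave open what a longer chain in place of the ethyl of 4-ethylphenyl, or an amine or a carboxylic acid in place of the hydroxy of 2-hydroxyphenyl, would give in this assay.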